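This account rests on a few compounds, and the source may have more. Where it says the series, first, only, none or still open, it means among the compounds named here.

Series measured in a functional assay on SW480 cells (Homo sapiens) for antiproliferative activity, read by MTT assay, with a stated time of 48 h; a higher number here means a weaker inhibitor, a lower number a stronger inhibitor:
- compound 1 `CCCCCCCCC[C@H](CCOS(C)(=O)=O)n1cnc2c(Cl)ncnc21`: 9720 nM
- compound 2 `CCCCCCCCC[C@H](CCn1cc(-c2ccccc2)nn1)n1cnc2c(Cl)ncnc21`: 8570 nM
- compound 3 `CCCCCCCCCC(CCCl)n1cnc2c(Cl)ncnc21`: 7180 nM

Compound 3 stands within the scatter of both compound 1 and compound 2, so the three values do not separate on this assay.

The next compound, not yet measured, is compound 4 `CCCCCCCCC[C@H](CCCl)n1cnc2c(Cl)ncnc21`. The change is the two compounds have the same atoms and bonds; at least one stereo element is drawn with a configuration in one of them and without one in the other: 1 of 1 stereo elements differ; a stereocentre at a saturated chain carbon is drawn without a configuration in compound 3 and R in compound 4. The atoms and bonds stay the same, and only the drawn configuration differs.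

Among the compounds with values here, only one measured step is available: a 1.1-fold lower number from compound 1 to compound 2 (0.05 log units; within the scatter). Within the data shown here, it concerns a different change, at the chain end, and no measured pair isolates a change in stereo drawing. It therefore bears on this question only indirectly, showing that a change of group at that chain end left the value within the scatter.

No step beyond the scatter is expected, and no direction can be assigned. The starting point is compound 3 at 7180 nM.

The expected step is a 1.0-fold higher number from compound 3 to compound 4 (0.02 log units; within the scatter). For compound 4 the estimated value is 7500 nM, with an expected range of 4500 nM to 12500 nM.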

Compound 4, half-maximal inhibitory concentration: 3180 nM
For compound 4 the middle estimate is 2.4-fold (0.37 log units) above the measured one, outside the stated range (below it).
By their numbers in this assay, from the lowest: compound 4; then compounds 3, 2 and 1 (each within the scatter of the next).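

In this assay, within the data shown here, the stereocentre at the saturated chain carbon carries weight, with a 2.3-fold lower number from compound 3 to compound 4 (0.35 log units; beyond the scatter) as the first step beyond the scatter, whereas compounds 1, 2 and 3 stood within the scatter of one another. With the R configuration drawn, the chain-end group also registers: chloro gives a 2.7-fold lower number from compound 2 to compound 4 (0.43 log units; beyond the scatter) when it replaces 4-phenyl-1H-1,2,3-triazol-1-yl and a 3.1-fold lower number from compound 1 to compound 4 (0.49 log units; beyond the scatter) when it replaces (methylsulfonyl)oxy, although compounds 1 and 2 differ from each other only within the scatter. The single structural difference on record for the stereo step is one of drawing: the fact that one of compounds 3 and 4 is drawn with a defined configuration and the other without, at the place where they differ.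

Going by these compounds, the value of the S configuration at this carbon remains open, as does the stereochemical composition of compound 3. Also open, on these data alone, is whether an amine or a hydroxyl at the chain end would match chloro.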